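The source may report more compounds than this note shows. Statements on the series, on what has been measured and on what is new or still open speak of the compounds shown alone.

In a functional assay on SNO cells (Homo sapiens) for cytotoxicity, read by XTT assay, with a stated time of 24 h (on this read-out lower numbers stand for stronger inhibition and higher numbers for weaker inhibition), compound 1 (`CC(=O)Oc1cc(C)c(Cl)c2c1C(=O)C=CC2=O`) gives 28800 nM, compound 2 (`COc1cc(C)c(Cl)c2c1C(=O)C=CC2=O`) gives 24600 nM and compound 3 (`CCOc1cc(C)cc2c1C(=O)C=CC2=O`) gives 25300 nM. Compound 3 thus stands within the scatter of both other compounds, and the three values show no order.

Compound 4 (`CCOc1cc(C)c(Cl)c2c1C(=O)C=CC2=O`) has chloro in place of hydrogen on an aromatic carbon, ortho to a methyl group and para to an ethoxy group: chloro in place of hydrogen on an aromatic carbon.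

For the measured compounds named here, the only measured single-place step is a 1.2-fold lower number from compound 1 to compound 2 (0.07 log units; within the scatter), methyl in place of acetyl on an oxygen on an aromatic ring. It lies within the scatter and does not test chloro directly. Compound 2 carries chloro and gives 24600 nM, while compound 3 lacks it and gives 25300 nM. These two also differ on the oxygen, so they offer only indirect evidence, but their values lie within the scatter of each other.

No step beyond the scatter is therefore expected in this assay. The expected change is a 1.1-fold lower number from compound 3 to compound 4 (0.02 log units; within the scatter). Compound 4 is estimated at 24000 nM, with an expected range of 14000 nM to 41000 nM.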

Compound 4, half-maximal inhibitory concentration: 44200 nM
Estimate against measurement, compound 4: 1.8-fold (0.27 log units) below; the measured number lies above the stated range.
By their numbers in this assay, from the lowest: compounds 2, 3, 1 and 4 (each within the scatter of the next).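

In this assay the only direct test of chloro on this aromatic carbon, ortho to a methyl group and para to an ethoxy group, gives a 1.7-fold higher number from compound 3 to compound 4 (0.24 log units; within the scatter) and so does not separate the chloro compound from its hydrogen partner. With chloro kept, the changes on the oxygen give a 1.8-fold higher number from compound 2 to compound 4 (0.25 log units; within the scatter) and a 1.5-fold higher number from compound 1 to compound 4 (0.19 log units; within the scatter) and also remain inside the usual spread, so neither this position nor the group on that oxygen yet orders the series. Nothing measured here offers an explanation for these numbers.

Going by these compounds, whether chloro behaves the same way with methoxy or acetyl on the oxygen remains open, as these compounds have no hydrogen partner here. Also open, on these data alone, is whether bromo at this place, or a longer chain or an amine on the oxygen, would give a step beyond the scatter.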